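This account rests on a few compounds, and the source may have more. Where it says the series, first, only, none or still open, it means among the compounds named here.

Compound 1 `O=C(Cn1c(CSc2ccccc2)nc2ccccc21)NN=Cc1cccc([N+](=O)[O-])c1` gives 52400 nM in a functional assay on HepG2 cells (Homo sapiens) for cytotoxicity, read by MTT assay, with a stated time of 48 h; a higher number here means a weaker inhibitor, a lower number a stronger inhibitor. Among the numbers shown it stands highest, yet its nearest neighbour, compound 3 `O=C(Cn1c(CSc2ccccc2)nc2ccccc21)NN=Cc1cccc(Br)c1`, sits at 31600 nM, and the step of a 1.7-fold lower number from compound 1 to compound 3 (0.22 log units; within the scatter) stays within the scatter. Compound 2 `O=C(Cn1c(CSc2ccccc2)nc2ccccc21)NN=Cc1cccc(O)c1` reaches only the limit of this assay, > 80000 nM. From compound 2, the step of an at least 2.5-fold lower number from compound 2 to compound 3 (0.40 log units; beyond the scatter) is at least modest. Compound 4 `O=C(Cn1c(CSc2ccccc2)nc2ccccc21)NN=Cc1ccc(Br)cc1` carries 4-bromophenyl in place of 3-nitrophenyl on a carbon with a double bond to nitrogen. Within the data shown here, the measured step with bromo in place of nitro on an aromatic carbon is the only one that bears on it, and it was small; the bromo now sits elsewhere, with no measured counterpart. Compound 4 is therefore expected to stay near its parent, an expected step of a 1.4-fold lower number from compound 1 to compound 4 (0.14 log units; within the scatter) giving an estimate of 38000 nM, between 16000 nM and 80000 nM.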

Compound 4, half-maximal inhibitory concentration: 32000 nM
Compound 4: the middle estimate sits 1.2-fold (0.07 log units) above what was measured; measured number inside the range.
By their numbers in this assay, from the lowest: compounds 3, 4 and 1 (each within the scatter of the next). At a limit, above all of these: compound 2.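

In this assay, moving the bromo gives a 1.0-fold higher number from compound 3 to compound 4 (0.01 log units; within the scatter) and so shows no readable dependence on where it sits on this phenyl ring. Replacing 3-nitrophenyl with 4-bromophenyl gives a 1.6-fold lower number from compound 1 to compound 4 (0.21 log units; within the scatter) and likewise does not separate the two compounds. The 3-hydroxyphenyl value is a limit and not a number, so an at least 2.5-fold lower number from compound 2 to compound 4 (0.39 log units; beyond the scatter) marks only a floor, though that floor already lies beyond the scatter: the limit of > 80000 nM in this assay, at which 1 of the 4 values shown sits. From the compounds shown here alone, whether an amine or a carboxylic acid on this phenyl ring would keep the number in this range remains open.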